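A few compounds are considered here, and "the series" means these few. Any claim that something is new, unique, unknown or untested is made for them only; others in the source may bear on it.

Values in a functional assay on the whole organism (strain Sprague-Dawley) for inhibition, with Rattus norvegicus as the target, with a stated time of 10 min (a higher number here means that more compound is needed for the effect, a lower number that less compound is needed), for the measured compounds:
- compound 1 `CCOc1ccc(Cl)cc1-c1ncc(C(=O)O)c(=O)[nH]1` gives 0.5 mg/kg
- compound 2 `CCOc1ccc(N(C)C)cc1-c1ncc(C(=O)O)c(=O)[nH]1` gives 0.3 mg/kg
- compound 3 `CCOC(=O)C(=O)Nc1ccc(OCC)c(-c2ncc(C(=O)O)c(=O)[nH]2)c1` gives 25 mg/kg

Compound 3 has the highest number of the three, so the most compound is needed for the effect. Compound 4 `CCOc1ccc(S(=O)(=O)N(C)C(C)C)cc1-c1ncc(C(=O)O)c(=O)[nH]1` carries isopropyl(methyl)sulfamoyl in place of ((ethoxycarbonyl)carbonyl)amino on an aromatic carbon. Among the measured compounds shown here, no measured step involves this sulfamoyl group, so the guidance is indirect. Putting ((ethoxycarbonyl)carbonyl)amino in place of chloro or dimethylamino raised the number sharply (a 50-fold higher number from compound 1 to compound 3 (1.70 log units; beyond the scatter) and an 83-fold higher number from compound 2 to compound 3 (1.92 log units; beyond the scatter)), whereas the remaining step stays within the scatter (a 1.7-fold lower number from compound 1 to compound 2 (0.22 log units; within the scatter)). Removing that group therefore points to a large downward step in this assay for this change. The estimated step is a 17-fold lower number from compound 3 to compound 4 (1.22 log units; beyond the scatter) with wide uncertainty. For compound 4 the expected value is 1.5 mg/kg (range 0.3 mg/kg to 10 mg/kg).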

Compound 4, dose for 50% inhibition: > 10 mg/kg
Compound 4: only a limit was reported; the forecaster's own chance of this, stated with the estimate: 5%; middle value at least 6.6-fold (0.82 log units) away from the limit.
By their numbers in this assay, from the lowest: compounds 2 and 1 (each within the scatter of the next); then compound 3.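

Compound 4 has only a limit in this assay, not a number: the limit of > 10 mg/kg in this assay, at which 1 of the 4 values shown sits.

Even so, with isopropyl(methyl)sulfamoyl in place of chloro there is an at least 20-fold higher number from compound 1 to compound 4 (1.30 log units; beyond the scatter) and with it in place of dimethylamino there is an at least 33-fold higher number from compound 2 to compound 4 (1.52 log units; beyond the scatter) so a large rise at this place, para to an ethoxy group, is no longer seen with compound 3 alone. The step from compound 3 to compound 4 cannot be read, so these two compounds cannot be ordered. From the compounds shown here alone, whether a primary amine or an unsubstituted sulfamoyl group at this place would stay close to compound 1 and compound 2 remains open.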